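The compounds below may be only part of what the source reports. "The series", "measured", "known", "first", "only" and "open" are said of these compounds alone.

Measured compounds:
compound 1 `CN1CCC(c2ccc3c(c2)oc(=O)n3C(=O)NCCCCc2ccc(F)cc2)CC1`, 22000 nM
compound 2 `CC(C)CNC(=O)n1c(=O)oc2c(C3CCN(C)CC3)cccc21`, 230000 nM
compound 3 `CCCCCNC(=O)n1c(=O)oc2cc(-c3ccc(F)cc3)ccc21`, < 1000 nM

In a physicochemical assay for solubility, read by HPLC, in phosphate buffer, measured as kinetic solubility, with a stated time of 1 h, at pH 7.4, tested at 250 uM (on this read-out lower numbers stand for lower solubility and higher numbers for higher solubility), compound 1 gives 22000 nM, the lower of the two numbers shown; the nearest number belongs to compound 2, which gives 230000 nM, a gap beyond the scatter. For compound 3 the assay reports only a limit, (the limit of < 1000 nM in this assay, at which 1 of the 3 values shown sits). Compound 4 `CN1CCC(c2ccc3c(c2)oc(=O)n3C(=O)NCCCCc2ccccc2)CC1` differs from compound 1 by hydrogen in place of fluoro on an aromatic carbon. Within the data shown here, no measured pair in this set isolates that change, so its size cannot be read from these data. In this assay no step beyond the scatter is expected, with perhaps a small rise in solubility. Compound 4 is estimated at 28000 nM, range 12000 nM to 60000 nM. The expected step is a 1.3-fold higher number from compound 1 to compound 4 (0.10 log units; within the scatter).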

Compound 4, solubility: 120000 nM
Estimate against measurement, compound 4: 4.3-fold (0.63 log units) below; the measured number lies above the stated range.
By their numbers in this assay, from the lowest: compound 1; then compounds 4 and 2 (each within the scatter of the next). At a limit, below all of these: compound 3.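

In this assay, hydrogen in place of fluoro on the aromatic carbon of the 4-fluorophenyl end gives a 5.5-fold higher number from compound 1 to compound 4 (0.74 log units; beyond the scatter), so this position is not silent on this read-out, even for a change of one heavy atom. Among these compounds, this is the first pair that differs in one place, and the reading of the position rests on it alone. Nothing measured here accounts for the step.

As far as these compounds go, whether chloro or methoxy on this carbon would give a step of like size stays open. So does whether the same change holds with a longer chain.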